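Swapping the ketone for a hydroxy group on the shared core

The compounds below may be only part of what the source reports. "The series", "measured", "known", "first", "only" and "open" are said of these compounds alone.

Compound 2 `CC1(C)C=C(n2ccccc2=O)c2cc(C(=O)c3ccco3)ccc2O1` gives 6.49 in a functional assay (aorta) with Rattus norvegicus as the target; a lower number here means a less potent compound, a higher number a more potent compound, by a factor of ten per unit of this negative logarithm; compound 1 `COc1ccc(C(=O)c2ccc3c(c2)C(n2ccccc2=O)=CC(C)(C)O3)cc1` gives 6.15.

Compound 2 has the highest number of the two; it lies a number 0.34 log units higher from compound 1 to compound 2 (beyond the scatter). Compound 3 `CC1(C)C=C(n2ccccc2=O)c2cc(O)ccc2O1` differs from compound 2 in one place: hydroxy in place of (furan-2-yl)carbonyl on an aromatic carbon. Going by the values given here, the only measured step swaps one aryl group for another on the same carbonyl carbon; no step removes the carbonyl unit itself, so nothing measured bears directly on this change. Because compound 2 sits at 6.49 with the larger group present, a drop is expected, by a number 0.89 log units lower from compound 2 to compound 3 (beyond the scatter). Compound 3 is estimated at 5.6, between 4.8 and 6.4.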

Compound 3, logarithm of the reciprocal of the active concentration, log(1/C): 5.44
Compound 3: the middle estimate sits 0.16 log units above what was measured; the range from low to high includes it.
By their numbers in this assay, from the lowest: compound 3; then compound 1; then compound 2.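

In this assay, hydroxy in place of (furan-2-yl)carbonyl on this aromatic carbon gives a number 1.05 log units lower from compound 2 to compound 3 (beyond the scatter), a large step, whereas exchanging only the aryl group on the carbonyl carbon gave the modest a number 0.34 log units higher from compound 1 to compound 2 (beyond the scatter). Across these compounds, then, removing the whole unit costs more than changing the aryl group it carries. Nothing measured here gives a reason for this drop.

The compounds shown leave open whether the carbonyl or the attached ring accounts for the difference. An acetyl group, which keeps a carbonyl but has no ring, or an amine in place of hydroxy could still read either way in this assay on this core.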